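A Longer Chain Where Every Value Is a Limit

The source may report more compounds than this note shows. Statements on the series, on what has been measured and on what is new or still open speak of the compounds shown alone.

Three compounds share one core and differ only in the length of a saturated chain attached to a carbonyl. Compound 1 is `CCCCCCC(=O)c1cc(O)c(O)c(O)c1`, compound 2 is `CCCCCCCCC(=O)c1cc(O)c(O)c(O)c1`, and compound 3 is `CCCCCCCCCCCCC(=O)c1cc(O)c(O)c(O)c1`. In a toxicity assay on Vero cells (Chlorocebus sabaeus) (a higher number here means a weaker inhibitor, a lower number a stronger inhibitor), compound 1 reaches only the limit of the assay, > 299000 nM. In this assay compound 2 likewise stops at the limit, > 299000 nM. In this assay compound 3 too gives only the limit, > 299000 nM. Because the limit of > 299000 nM in this assay, at which 3 of the 3 values shown sit, none of the steps between them can be read: the change from compound 1 to compound 2, (ethyl in place of hydrogen on a saturated chain carbon, six bonds along the chain from a carbonyl carbon), gives a step that the two limits leave unreadable from compound 1 to compound 2, and the difference between the cores of compound 1 and compound 3, (hexyl in place of hydrogen on a saturated chain carbon, six bonds along the chain from a carbonyl carbon), gives a step that the two limits leave unreadable from compound 1 to compound 3.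

The unmeasured compound 4 is `CCCCCCCCCCCCCCC(=O)c1cc(O)c(O)c(O)c1`. It differs from compound 3 by ethyl in place of hydrogen on a saturated chain carbon, ten or more bonds along the chain from a carbonyl carbon. This is the same kind of change as that from compound 1 to compound 2, though it sits at a different place along the chain. Since all three measured values are limits rather than numbers, there is no readable step on which to base a size; the step is expected to be a step that the limit leaves unreadable from compound 3 to compound 4, set beside a step that the two limits leave unreadable from compound 1 to compound 2, and this rests only on the three limits. Compound 4 is expected to give 400000 nM, within a range from 150000 nM to 1000000 nM, and most likely once more only a limit.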

Compound 4, half-maximal inhibitory concentration: > 299000 nM
Compound 4 ended at the assay's limit (the forecaster's own chance of this, stated with the estimate: 85%); the middle value lies beyond the limit too.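

No new step can be read between compound 4 and compound 1, compound 2 or compound 3, because all four compounds stop at the same limit rather than giving a number: the limit of > 299000 nM in this assay, at which 4 of the 4 values shown sit.

The compounds shown leave open whether the length of the saturated chain changes the result in this assay at all, and how far apart any of these four compounds truly lie.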